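Ester chain extension from compound 3 to compound 4

This account rests on a few compounds, and the source may have more. Where it says the series, first, only, none or still open, it means among the compounds named here.

Three members of the series have numbers in an assay on membranes from CHO cells for displacement of a labelled ligand from adenosine receptor A1 (Homo sapiens), read by scintillation counting, with a stated time of 60 min, tested at 1 uM; on this read-out higher numbers stand for more inhibition at the one concentration tested (going by the name of the read-out) and lower numbers for less inhibition. Compound 1 `CCCOC(=O)C1=C(C)NC(=O)NC1c1ccoc1` gives 50%, compound 2 `CCCOC(=O)C1=C(C)N(C)C(=O)NC1c1ccco1` gives 3%, and compound 3 `COC(=O)C1=C(C)N(C)C(=O)NC1c1ccoc1` gives 15%. On these three numbers compound 3 stands second highest: its nearest neighbour is compound 2, whose number lies lower by a margin beyond the usual scatter, and its furthest is compound 1, whose number lies higher, again beyond the scatter. Among the compounds with values here, no two of the measured compounds differ in a single place, so no step between measured compounds can be read off.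

Compound 4 `CCCOC(=O)C1=C(C)N(C)C(=O)NC1c1ccoc1` is not yet measured in this assay. It differs from compound 3 by ethyl in place of hydrogen on a saturated chain carbon bound to an oxygen next to a carbonyl group. Compound 2 also carries a propoxycarbonyl group, though it differs from compound 4 elsewhere, and compound 2 gives 3%; compound 1 carries a propoxycarbonyl group as well and gives 50%.

Within the data shown here, with no measured step for methoxycarbonyl to propoxycarbonyl available, the step is expected to be small: a change of a number 3 percentage points lower from compound 3 to compound 4 (within the scatter) is expected, within the scatter, leaning slightly downward because compound 2 with its propoxycarbonyl group gives 3%. For compound 4 the expected value in this assay is 12%, with a range from 0% to 35%.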

Compound 4, a percentage reported as inhibition, at one concentration (the size of the read-out at that concentration, not a potency): 1%
Compound 4: the middle estimate sits 11 percentage points above what was measured; the range from low to high includes it.
By their numbers in this assay, from the lowest: compounds 4 and 2 (each within the scatter of the next); then compound 3; then compound 1.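

In this assay, within the data shown here, the change from methoxycarbonyl to propoxycarbonyl, ethyl in place of hydrogen on a saturated chain carbon bound to an oxygen next to a carbonyl group, gives a number 14 percentage points lower from compound 3 to compound 4 (beyond the scatter) and is the first single-place reading of this position; with methyl on the amide-type nitrogen in a ring, the longer ester gives no gain in inhibition and a modest loss. Furan-3-yl in place of furan-2-yl on a saturated ring carbon gives a number 2 percentage points lower from compound 2 to compound 4 (within the scatter), so with the propoxycarbonyl group and that nitrogen methyl in place, the two furan attachments cannot be told apart on this read-out. Methyl in place of hydrogen on an amide-type nitrogen in a ring gives a number 49 percentage points lower from compound 1 to compound 4 (beyond the scatter), the large step of the set, which places the nitrogen substituent ahead of the ester chain as the change with the bigger reading among these steps.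

Open, going by these compounds, is whether the ester step keeps its size on the core carrying the amide hydrogen, and how a butoxycarbonyl chain or a carboxylic acid at the ester position would read. No measurement at hand speaks to the reason for any of these steps.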